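Swapping an Aminophenyl for Thiophene on a Triazole Series

The source may hold more compounds than are shown below. What is called first, only, known or untested is meant among the compounds shown, and "the series" means these compounds.

Two compounds from this series have been characterised in a functional assay on BMDM cells (Mus musculus, strain C57BL/6) for inhibition, with a stated time of 2 days; a higher number here means a weaker inhibitor, a lower number a stronger inhibitor. Compound 1 `Nc1cccc(-c2cn(CC(=O)Nc3nc4ccccc4s3)nn2)c1` gives 1110 nM. Compound 2 `Cc1csc(NC(=O)Cn2cc(-c3ccccc3Cl)nn2)n1` gives 1240 nM, a number that sits within the usual scatter of the value for compound 1, so the two cannot be told apart on this assay. Compound 3 `O=C(Cn1cc(-c2cccs2)nn1)Nc1nc2ccccc2s1` has not yet been measured. It differs from compound 1 in a single way: thiophen-2-yl in place of 3-aminophenyl on an aromatic carbon. With no step between measured compounds available, the size of this change can only be judged from the two numbers shown, which differ by little. The author expects compound 3 to remain close to compound 1, with an estimated step of a 1.4-fold higher number from compound 1 to compound 3 (0.13 log units; within the scatter) in this assay, and estimates a value of 1500 nM for compound 3, within a range from 500 nM to 5000 nM.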

Compound 3, half-maximal inhibitory concentration: 21400 nM
Estimate against measurement, compound 3: 14-fold (1.15 log units) below, outside the stated range (above it).
By their numbers in this assay, from the lowest: compounds 1 and 2 (each within the scatter of the next); then compound 3.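

In this assay the result shows that this aromatic carbon does not accept every aromatic group equally: thiophen-2-yl in place of 3-aminophenyl produces a 19-fold higher number from compound 1 to compound 3 (1.29 log units; beyond the scatter) and so marks the position as sensitive to this change, which the two earlier numbers alone could not show. The swap replaces a six-membered aromatic ring of carbon only, bearing a hydrogen-bond donor, with a five-membered aromatic ring with 1 hetero atom and 0 hydrogen-bond donors, so the ring and the amine change together in this one step. No measurement available here bears on why the step is so large.

The compounds shown leave open whether the amine or the ring accounts for the step. An unsubstituted phenyl group, or a thiophen-2-yl carrying an amine, at this carbon would separate the two.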